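The source may hold more compounds than are shown below. What is called first, only, known or untested is meant among the compounds shown, and "the series" means these compounds.

Measured in a physicochemical assay for lipophilicity, using the shake flask method; a higher number here means a more lipophilic compound, a lower number a more polar compound:
- compound 1 `C[C@H](Oc1ccc2ncc(/C=C/C(=O)O)c(C3CC3)c2c1)c1c(Cl)cccc1Cl` gives 3.7
- compound 2 `C[C@H](Oc1ccc2ncc(/C=C/S(=O)(=O)O)c(C3CC3)c2c1)c1c(Cl)ccc(F)c1Cl` gives 2.5
- compound 3 `C[C@H](Oc1ccc2ncc(/C=C/C(=O)O)c(C#N)c2c1)c1c(Cl)ccc(F)c1Cl` gives 2.3

Compound 3 at 2.3 and compound 2 at 2.5 lie within the usual scatter of each other, so these two cannot be told apart. Compound 1 at 3.7 stands higher than compound 3, and that gap lies beyond the scatter.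

Compound 4 `C[C@H](Oc1ccc2ncc(/C=C/C(=O)O)c(C3CC3)c2c1)c1c(Cl)ccc(F)c1Cl` has not been measured yet. It differs from compound 3 in one place, with cyclopropyl in place of cyano on an aromatic carbon, opposite the ring nitrogen (cyclopropyl in place of cyano on an aromatic carbon).

Among the compounds with values here, no two measured compounds differ in one place only, so the data hold no direct example of this step. The nearest guide is compound 1, which carries cyclopropyl on that carbon and gives 3.7, a value that points upward. Compound 2 goes against this reading: it carries cyclopropyl there too, yet gives 2.5. On balance, a rise in this assay beyond the scatter is expected, and the estimated step is a number 1.40 log units higher from compound 3 to compound 4 (beyond the scatter). For compound 4 the estimated value is 3.7, with an expected range from 3.2 to 4.2.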

Compound 4, distribution coefficient: 4.1
Compound 4: middle estimate off by 0.40 log units, on the low side; measured number inside the range.
By their numbers in this assay, from the lowest: compounds 3 and 2 (each within the scatter of the next); then compound 1; then compound 4.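

In this assay the carbon opposite the ring nitrogen now has a direct comparison: cyclopropyl in place of cyano gives a number 1.80 log units higher from compound 3 to compound 4 (beyond the scatter) and so a single change at this place, with the rest of the molecule the same, is enough for a large step. Cyclopropyl on that carbon does not settle the number alone, as carboxy in place of sulfo on the chain gives a number 1.60 log units higher from compound 2 to compound 4 (beyond the scatter) while both compounds carry cyclopropyl there, and fluoro in place of hydrogen on an aromatic carbon gives a modest a number 0.40 log units higher from compound 1 to compound 4 (beyond the scatter) as well. Nothing measured here says what lies behind the size of these steps. With only cyano and cyclopropyl compared on this carbon, the compounds shown leave open where a methyl group, a chlorine atom or an amine would fall in this assay on the same core. As far as these compounds go, each change is also seen only once, on a single background, so it remains open whether the step from cyano to cyclopropyl would be as large with sulfo in place of carboxy on the chain.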